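This account rests on a few compounds, and the source may have more. Where it says the series, first, only, none or still open, it means among the compounds named here.

Compound 1, `COC(C(=O)OC(C)Cn1cnc2c1c(=O)n(C)c(=O)n2C)c1cccc2ccccc12`, and compound 2, `COC(C(=O)OC(C)Cn1cnc2c1c(=O)n(C)c(=O)n2C)c1ccc2ccccc2c1`, share the same core and differ only in how the naphthalene is attached. In a functional assay on MCF7 cells (Homo sapiens) for antiproliferative activity, read by MTT assay, with a stated time of 72 h, tested at 200 uM (a higher number here means a weaker effect of the compound at the concentration tested, a lower number a stronger effect), compound 1 gives 76.9%, while compound 2 gives 68.8%. The step of a number 8.1 percentage points lower from compound 1 to compound 2 (within the scatter) is therefore too small to tell the two apart. Compound 2 stands lowest of the two numbers shown, but its nearest neighbour, compound 1, sits within the scatter, so no real difference between them can be claimed.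

Compound 3, `COC(C(=O)OC(C)Cn1cnc2c1c(=O)n(C)c(=O)n2C)c1ccc(C(C)(C)C)cc1`, has not yet been measured. It differs from compound 2 by 4-(tert-butyl)phenyl in place of naphthalen-2-yl on a saturated chain carbon bound to a carbonyl carbon and an oxygen on a saturated carbon. For the measured compounds named here, the only measured step moved the attachment point of a two-ring aromatic group and stayed within the scatter; no measured step addresses exchanging that two-ring group for a single six-membered aromatic ring carrying a tert-butyl group. With nothing bearing on this exchange, the expectation for compound 3 rests on compound 2 alone and is a step of a number 1.2 percentage points higher from compound 2 to compound 3 (within the scatter), none beyond the scatter. Compound 3 is thus estimated at 70%, between 45% and 95%.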

Compound 3, a percentage reported as activity, at one concentration (the size of the read-out at that concentration, not a potency): 35%
Compound 3: the middle estimate sits 35 percentage points above what was measured; measured number below the stated range.
By their numbers in this assay, from the lowest: compound 3; then compounds 2 and 1 (each within the scatter of the next).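

For the compounds shown here, replacing a two-ring naphthalene with 4-(tert-butyl)phenyl on the saturated chain carbon bound to a carbonyl carbon and an oxygen on a saturated carbon is the first change here to move the read-out clearly in this assay: it gives a step of a number 33.8 percentage points lower from compound 2 to compound 3 (beyond the scatter) and a step of a number 41.9 percentage points lower from compound 1 to compound 3 (beyond the scatter), and in this assay a lower number means a stronger effect. So this position responds to the identity of its group, even though the earlier switch between the two naphthalene attachments gave no step beyond the scatter, and the groups exchanged here have the same count of 10 heavy atoms, all carbon, but one six-membered aromatic ring instead of two. No measurement shown here explains why this exchange matters so much.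

The three compounds cannot separate the effect of losing the second ring from that of gaining the tert-butyl group, and an unsubstituted phenyl or a 4-methylphenyl group at this place would bear on that question. Going by these compounds, how a group carrying an amine or a carboxylic acid would read at this place also remains open.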